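Amine substituent on the piperazine and microsomal stability

The source may hold more compounds than are shown below. What is called first, only, known or untested is meant among the compounds shown, and "the series" means these compounds.

Measured compounds:
compound 1 `COc1cc(C)c(S(=O)(=O)N(C)CCOCC(=O)N2CCN(C3CCN(C4CC4)CC3)CC2)c(C)c1`, 6%
compound 2 `CCN(CC)CCN1CCN(C(=O)COCCN(C)S(=O)(=O)c2c(C)cc(OC)cc2C)CC1`, 73%
compound 3 `COc1cc(C)c(S(=O)(=O)N(C)CCOCC(=O)N2CCN(CCCN(C)C)CC2)c(C)c1`, 67%

In an ADME assay on microsomes from liver (Homo sapiens) for metabolic stability, with a stated time of 30 min, tested at 1 uM (on this read-out lower numbers stand for a less stable compound and higher numbers for a more stable compound), compound 3 gives 67%, the second highest of the three numbers; compound 2 sits nearest with a number 6 percentage points lower from compound 2 to compound 3 (within the scatter), while compound 1 lies furthest with a number 61 percentage points higher from compound 1 to compound 3 (beyond the scatter).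

Compound 4 `COc1cc(C)c(S(=O)(=O)N(C)CCOCC(=O)N2CCN([C@H]3CN4CCC3CC4)CC2)c(C)c1` is not yet measured. Relative to compound 3 the change is a group of 8 heavy atoms (7 carbon, 1 nitrogen; 2 six-membered non-aromatic rings with 1 hetero atom each) in place of a group of 6 heavy atoms (5 carbon, 1 nitrogen; no ring), on an amine nitrogen in a ring.

Among the measured compounds shown here, two measured steps bear on this. Going from a group with a ring on that nitrogen to a chain gave a number 67 percentage points higher from compound 1 to compound 2 (beyond the scatter) and a number 61 percentage points higher from compound 1 to compound 3 (beyond the scatter), both large. Compound 4 goes the other way, from the chain back to a group with rings. For the measured compounds named here, a large step downward in this assay is therefore expected, a number 47 percentage points lower from compound 3 to compound 4 (beyond the scatter), with uncertainty since the entering group is not the one in compound 1. The value for compound 4 is estimated at 20%, within 5% to 45%.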

Compound 4, percent of the compound remaining: 26%
Estimate against measurement, compound 4: 6 percentage points below; low and high end bracket the measured number.
By their numbers in this assay, from the lowest: compound 1; then compound 4; then compounds 3 and 2 (each within the scatter of the next).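

In this assay, low numbers at this amine nitrogen in a ring are no longer confined to the 1-cyclopropylpiperidin-4-yl group, as the group with two six-membered non-aromatic rings also sits well under both chains (a number 41 percentage points lower from compound 3 to compound 4 (beyond the scatter); a number 47 percentage points lower from compound 2 to compound 4 (beyond the scatter)). Groups with rings still differ among themselves (a number 20 percentage points higher from compound 1 to compound 4 (beyond the scatter)), so the presence of rings on this nitrogen does not alone fix the number, although across these four compounds both chains stand above both groups with rings, with no compound going against that order. No available data bear on the reason for these steps.

Still open, as far as these compounds go, is how a 1-methylpiperidin-4-yl group or a longer chain such as 4-(dimethylamino)butyl would read at this nitrogen. Also open, from the compounds shown here alone, is whether the opposite stereoisomer of the group in compound 4 would give a similar number.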